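Bromo to trifluoromethyl on the indole ring of the series

The source may report more compounds than this note shows. Statements on the series, on what has been measured and on what is new or still open speak of the compounds shown alone.

Three esters of one shared core have been measured in a functional assay on WiDr cells (Homo sapiens) for inhibition, read by sulforhodamine B assay, with a stated time of 48 h; a higher number here means a weaker inhibitor of growth, a lower number a stronger inhibitor of growth. Compound 1 `COC(=O)[C@@]1(C)CCC=C2[C@@H]1CC[C@@H](C)[C@]2(C)Cc1c[nH]c2ccc(Br)cc12` gives 20000 nM. Compound 2 `COC(=O)[C@@]1(C)CCC=C2[C@@H]1CC[C@@H](C)[C@]2(C)Cc1c[nH]c2c(Cl)cccc12` gives 31000 nM. Compound 3 `COC(=O)[C@@]1(C)CCC=C2[C@@H]1CC[C@@H](C)[C@]2(C)Cc1c(C)[nH]c2ccc(Br)cc12` gives 15000 nM, the lowest number of the three; its gap to compound 1 is within the scatter, its gap to compound 2 is beyond it. Among the compounds with values here, the only single-point step measured, a 1.3-fold lower number from compound 1 to compound 3 (0.12 log units; within the scatter), shows that methyl in place of hydrogen on an aromatic carbon leaves the number essentially where it was.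

Compound 4 `COC(=O)[C@@]1(C)CCC=C2[C@@H]1CC[C@@H](C)[C@]2(C)Cc1c(C)[nH]c2ccc(C(F)(F)F)cc12` differs from compound 3 by trifluoromethyl in place of bromo on an aromatic carbon. No measured pair in the series exchanges one group for another at this carbon, so nothing shown bears directly on the change; the only comparison across substituents is compounds 1 and 2, which differ in both the group and its place. Within the data shown here, with no step to lean on, no change beyond the scatter is expected in this assay, and the estimated step of no change at the digits printed from compound 3 to compound 4 (within the scatter) is accordingly small. For compound 4 the expected value is 15000 nM, with a range from 5000 nM to 45000 nM.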

Compound 4, concentration for 50% growth inhibition: 21000 nM
Compound 4: middle estimate off by 1.4-fold (0.15 log units), on the low side; the range from low to high includes it.
By their numbers in this assay, from the lowest: compounds 3, 1, 4 and 2 (each within the scatter of the next, the first and the last beyond it).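

In this assay, within the data shown here, the step of a 1.4-fold higher number from compound 3 to compound 4 (0.15 log units; within the scatter) is the first measured exchange of one group for another at this aromatic carbon. Trifluoromethyl in place of bromo brings four heavy atoms where one stood, yet the number stays within the scatter, so with the methyl of compound 3 present, this carbon carries either group without a readable change. No accompanying measurement offers an explanation for this flat step.

As far as these compounds go, it remains open whether the same exchange would also stay within the scatter on compound 1, which has hydrogen in place of that methyl. Bromo and trifluoromethyl each count no hydrogen-bond donors or acceptors, so it is also open whether an amine or a carboxylic acid at this carbon would move the number beyond the scatter.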